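From Aryl Sulfone to Sulfonamide on a Shared Core

The source may report more compounds than this note shows. Statements on the series, on what has been measured and on what is new or still open speak of the compounds shown alone.

Two compounds share one core. Compound 1, `Cn1c(=O)c(S(=O)(=O)Cc2ccc(F)cc2F)cc2cnc(Nc3ccc4[nH]ccc4c3)nc21`, gives in a functional assay on K562 cells (Homo sapiens) for inhibition, read by trypan blue exclusion, with a stated time of 72 h (a higher number here means a weaker inhibitor, a lower number a stronger inhibitor), a value of 1000 nM. Compound 2, `Cc1ccc(S(=O)(=O)c2cc3cnc(Nc4ccc5[nH]ccc5c4)nc3n(C)c2=O)cc1`, gives in this assay a value of 750 nM. The step of a 1.3-fold lower number from compound 1 to compound 2 (0.12 log units; within the scatter) lies within the scatter, so compound 2 holds the lower of the two numbers without being set apart from compound 1. Compound 3, `Cn1c(=O)c(S(=O)(=O)Nc2ccc(F)cc2F)cc2cnc(Nc3ccc4[nH]ccc4c3)nc21`, has not yet been measured. It differs from compound 2 by (2,4-difluorophenyl)amino in place of 4-methylphenyl on a sulfonyl sulfur. Going by the values given here, the only measured step at the sulfonyl sulfur, a 1.3-fold lower number from compound 1 to compound 2 (0.12 log units; within the scatter), was small, and it exchanged 2,4-difluorobenzyl for 4-methylphenyl; no measured step covers an amino link at this position. One therefore expects no step beyond the scatter, a 1.2-fold higher number from compound 2 to compound 3 (0.08 log units; within the scatter). For compound 3 the estimate in this assay is 900 nM, with a range from 300 nM to 3000 nM.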

Compound 3, half-maximal inhibitory concentration: 5000 nM
Beside the measured number, compound 3's estimate is 5.6-fold (0.74 log units) below it; the measured number lies above the stated range.
By their numbers in this assay, from the lowest: compounds 2 and 1 (each within the scatter of the next); then compound 3.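

The sulfonyl sulfur had shown no step beyond the scatter, but in this assay this position does respond to the group attached: the exchange of 4-methylphenyl gives a clear rise (a 6.7-fold higher number from compound 2 to compound 3 (0.82 log units; beyond the scatter)). The exchange of 2,4-difluorobenzyl gives a rise of similar kind (a 5.0-fold higher number from compound 1 to compound 3 (0.70 log units; beyond the scatter)), and here the 2,4-difluorophenyl ring stays in both compounds, so the change lies in its link to the sulfur. Nothing available explains why the amino link goes with the higher number.

Going by these compounds, it remains open whether the rise would persist with a methylamino link or with an oxygen link in the same place. On these data alone, it is also open whether an unsubstituted phenylamino group or a simple alkylamine on the sulfonyl sulfur would give a number like that of compound 3.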